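This account rests on a few compounds, and the source may have more. Where it says the series, first, only, none or still open, it means among the compounds named here.

The measured compounds:
compound 1, `CC(C)(C)c1cc(NC(=O)Nc2ccc(Nc3ncnc4c3OCCN4)cc2)no1`, 10 nM
compound 2, `Cc1cc(NC(=O)Nc2cc(C(C)(C)C)on2)ccc1Nc1ncnc2c1OCCN2`, 50 nM
compound 3, `CC(C)(C)c1cc(NC(=O)Nc2ccc(Nc3ncnc4c3OCCN4)nc2)no1`, 77 nM

All three were tested in an assay on isolated protein for inhibition of proto-oncogene tyrosine-protein kinase receptor Ret (Homo sapiens), read by 33P incorporation, with stated times of 15 min and 40 min; on this read-out lower numbers stand for stronger inhibition and higher numbers for weaker inhibition. Compound 4, `Cc1nc(Nc2ncnc3c2OCCN3)ccc1NC(=O)Nc1cc(C(C)(C)C)on1`, is yet to be measured there. The change from compound 1 to compound 2 is methyl in place of hydrogen on an aromatic carbon, and it produced a 5.0-fold higher number from compound 1 to compound 2 (0.70 log units; beyond the scatter). The change from compound 3 to compound 4 is methyl in place of hydrogen on an aromatic carbon. In compound 1 the ring is of carbon only, whereas in compound 3 it holds one nitrogen and the methyl enters next to the ring nitrogen, so this is the same kind of change rather than the same one. How the core of compound 1 differs from that of compound 3 is not broken down here. Compound 3 stands nearest to compound 2 and furthest from compound 1.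

Within the data shown here, the expected step is a 3.9-fold higher number from compound 3 to compound 4 (0.59 log units; beyond the scatter), which rests on the single known step of a 5.0-fold higher number from compound 1 to compound 2 (0.70 log units; beyond the scatter). Compound 4 is therefore estimated at 300 nM in this assay, with a range from 110 nM to 800 nM.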

Compound 4, half-maximal inhibitory concentration: 781 nM
Beside the measured number, compound 4's estimate is 2.6-fold (0.42 log units) below it; low and high end bracket the measured number.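

In this assay, methyl in place of hydrogen on an aromatic carbon also raised the number on the core of compound 3, giving a 10-fold higher number from compound 3 to compound 4 (1.01 log units; beyond the scatter). The step has the same direction as the earlier one, and the two do not differ in size beyond the scatter: the same change on two cores in this assay, a 5.0-fold higher number (0.70 log units; beyond the scatter) from compound 1 to compound 2 and a 10-fold higher number (1.01 log units; beyond the scatter) from compound 3 to compound 4, 2.0-fold (0.31 log units) apart, within the scatter of two such steps. Among these compounds, the change therefore carried over between these two cores, but with only one pair on each core, this does not show that it would carry to other cores, nor does it explain why the number rises.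

The compounds shown leave open whether ethyl, methoxy or a chlorine atom in place of that hydrogen would give a similar step. They also leave open how methyl would act elsewhere on the same ring.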